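This account rests on a few compounds, and the source may have more. Where it says the series, first, only, none or still open, it means among the compounds named here.

Working notes on the series. All three measured compounds share one core and differ only in the group carried on the five-membered ring. Compound 1 `COc1cc2ncnc(-n3nc(-c4ccncc4)nc3N)c2cc1OC` gives 5000 nM in an assay on MCF7 cells for inhibition of Serine-protein kinase ATM (Homo sapiens), read by immunofluorescence, with a stated time of 1 h; on this read-out lower numbers stand for stronger inhibition and higher numbers for weaker inhibition. Compound 2 `COc1cc2ncnc(-n3nc(-c4ccccc4)nc3N)c2cc1OC` gives 2000 nM in this assay, and the step of a 2.5-fold lower number from compound 1 to compound 2 (0.40 log units; beyond the scatter) is a modest one. Compound 3 `COc1cc2ncnc(-n3nc(-c4ccc(Cl)cc4)nc3N)c2cc1OC` stands at a limit of this assay and gives only > 40000 nM, which is the assay limit (the limit of > 40000 nM in this assay, at which 1 of the 3 values shown sits), not a number. The steps of an at least 8.0-fold higher number from compound 1 to compound 3 (0.90 log units; beyond the scatter) and an at least 20-fold higher number from compound 2 to compound 3 (1.30 log units; beyond the scatter) therefore place compound 3 beyond the scatter from both others, with no floor known for how far.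

Compound 4 `COc1cc2ncnc(-n3nc(C4CCCCC4)nc3N)c2cc1OC` is not yet measured. The change is cyclohexyl in place of 4-chlorophenyl on an aromatic carbon. Among the measured compounds shown here, none of the measured steps swaps an aromatic ring for a saturated ring, so they bear on this change only in fixing where compound 3 stands, and no direction can be drawn from them with confidence. Compound 4 is expected to lie near 20000 nM in this assay, somewhere between 3000 nM and 100000 nM. The expected step of an at least 2.0-fold lower number from compound 3 to compound 4 (0.30 log units; that floor lies within the scatter) is thus an estimate of no more than a modest move, with a real chance that compound 4 again reaches only a limit.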

Compound 4, half-maximal inhibitory concentration: > 40000 nM
Compound 4 was reported as a limit; the forecaster's own chance of this, stated with the estimate: 50%; at least 2.0-fold (0.30 log units) between middle value and limit.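

Compound 4 gives only a limit in this assay, not a number: the limit of > 40000 nM in this assay, at which 2 of the 4 values shown sit. Among the compounds shown here, this is the first non-aromatic ring at this position, and cyclohexyl in place of phenyl gives an at least 20-fold higher number from compound 2 to compound 4 (1.30 log units; beyond the scatter), while cyclohexyl in place of pyridin-4-yl gives an at least 8.0-fold higher number from compound 1 to compound 4 (0.90 log units; beyond the scatter). Of the six-membered rings shown on this aromatic carbon, only phenyl and pyridin-4-yl give readable values, so an aromatic ring is not enough on its own: compound 3 carries one and also stands at a limit.

The step between compound 3 and compound 4 cannot be read, which leaves 4-chlorophenyl and cyclohexyl unordered. As far as these compounds go, it also remains open how a methyl group or a morpholine ring on this carbon would compare with the phenyl of compound 2.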